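Aminopyridine in place of fluoropyridine on a kinase inhibitor scaffold

The compounds below may be only part of what the source reports. "The series", "measured", "known", "first", "only" and "open" are said of these compounds alone.

Measured so far:
compound 1 `COc1cccc(CN2CCc3cc(-c4ccc5[nH]ncc5c4)ccc3C2=O)c1` gives 632 nM
compound 2 `COc1cccc(Cn2cnc3sc(-c4ccnc(F)c4)cc3c2=O)c1` gives 83 nM
compound 3 `COc1cccc(Cn2cnc3sc(-c4ccnc(C)c4)cc3c2=O)c1` gives 42 nM

In an assay on isolated protein for inhibition of Rho-associated protein kinase 2 (Homo sapiens), read by radiometric assay and 33P incorporation, with a stated time of 40 min, in the presence of a further agent that is not named here (on this read-out higher numbers stand for weaker inhibition and lower numbers for stronger inhibition), compound 2 stands second highest of the three numbers. Its nearest neighbour is compound 3, separated by a 2.0-fold lower number from compound 2 to compound 3 (0.30 log units; within the scatter). Compound 1 lies furthest away; what its value of 632 nM shows against that of compound 2 is a gap beyond the scatter, with compound 2 giving the lower number.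

Compound 4 `COc1cccc(Cn2cnc3sc(-c4ccnc(N)c4)cc3c2=O)c1` has not been measured. It differs from compound 2 by amino in place of fluoro on an aromatic carbon, that is, an amino in place of fluoro on an aromatic carbon of the pyridine ring.

For the measured compounds named here, the only measured step that bears on this one is the change at the same carbon from compound 2 to compound 3, which was a 2.0-fold lower number from compound 2 to compound 3 (0.30 log units; within the scatter), within the scatter. A new substituent at the same place is therefore expected to move the number little, if at all, in this assay. The estimated step from compound 2 to compound 4 is a 1.5-fold lower number from compound 2 to compound 4 (0.18 log units; within the scatter). Compound 4 is expected to give about 55 nM, with a range from 15 nM to 200 nM.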

Compound 4, half-maximal inhibitory concentration: 1 nM
Estimate against measurement, compound 4: 55-fold (1.74 log units) above; the measured number lies below the stated range.
By their numbers in this assay, from the lowest: compound 4; then compounds 3 and 2 (each within the scatter of the next); then compound 1.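

Replacing fluoro with methyl on this carbon moved the number only within the scatter, so the position looked insensitive, but amino at the same place gives an 83-fold lower number from compound 2 to compound 4 (1.92 log units; beyond the scatter) and a 42-fold lower number from compound 3 to compound 4 (1.62 log units; beyond the scatter). This carbon, next to the ring nitrogen, can therefore strongly affect inhibition, and the outcome depends on which group sits there: among the three groups shown, only amino stands apart. Nothing available here explains the size of this step.

On these data alone, it remains open whether the effect needs an unsubstituted amino group, which a methylamino, dimethylamino or acetamido group at this carbon would help to test. As far as these compounds go, it is also open whether a hydroxyl or methoxy group there would behave more like amino or more like fluoro and methyl.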